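The source may hold more compounds than are shown below. What is called first, only, known or untested is meant among the compounds shown, and "the series" means these compounds.

Series notes. Compound 1 `COc1cc2c(CO)coc2cc1C` and compound 2 `COc1cc2c(CN)coc2cc1C` share one core and differ only on a saturated chain carbon bound to an aromatic carbon. In a functional assay on HEK293 cells for agonist activity at melatonin receptor type 1B (Homo sapiens), read by calcium flux (on this read-out lower numbers stand for an effect already at smaller amounts and higher numbers for an effect only at larger amounts of compound), compound 1 gives 520000 nM, and in this assay compound 2 gives 350000 nM. Within the data shown here, the step of a 1.5-fold lower number from compound 1 to compound 2 (0.17 log units; within the scatter) is the only measured step; the number for compound 2 lies within the scatter of that for compound 1, so the two cannot be told apart on these data. Compound 3 `COc1cc2c(CN3CCNCC3)coc2cc1C` has not been measured. Relative to compound 2 it carries piperazin-1-yl in place of amino on a saturated chain carbon bound to an aromatic carbon. Among the measured compounds shown here, no measured step bears directly on this change: the single step of a 1.5-fold lower number from compound 1 to compound 2 (0.17 log units; within the scatter) swaps hydroxy for amino at the same place and stays within the scatter, so it gives no direction for a larger group there. Both measured numbers sit at the high end of the range, and nothing in the series points to a move beyond the scatter. For compound 3 in this assay the expected step is a 1.2-fold lower number from compound 2 to compound 3 (0.07 log units; within the scatter). Compound 3 is therefore estimated at 300000 nM, with a range from 100000 nM to 1000000 nM.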

Compound 3, half-maximal effective concentration: 380000 nM
Estimate against measurement, compound 3: 1.3-fold (0.10 log units) below; measured number inside the range.
By their numbers in this assay, from the lowest: compounds 2, 3 and 1 (each within the scatter of the next).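

Working notes on the saturated chain carbon bound to an aromatic carbon: in this assay the larger group gives a 1.1-fold higher number from compound 2 to compound 3 (0.04 log units; within the scatter), although piperazin-1-yl brings six heavy atoms and a six-membered non-aromatic ring where amino has one heavy atom and no ring. Measured against hydroxy, the same group gives a 1.4-fold lower number from compound 1 to compound 3 (0.14 log units; within the scatter), so hydroxy, amino and piperazin-1-yl cannot be told apart at this place, and the added ring shows no effect that these data can resolve, a point the hydroxy-to-amino exchange alone could not address for a group of this size. No supporting data are available to account for this result.

Still open, going by these compounds, is whether any group at this place can produce a step beyond the scatter in this assay, for example a carboxylic acid, a longer chain ending in an amine, or a piperazine carrying a substituent on its second nitrogen. The compounds shown also leave open whether the same insensitivity holds once the rest of the shared core is altered.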